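Adding a chloro group to a fluorinated phenyl imide

This account rests on a few compounds, and the source may have more. Where it says the series, first, only, none or still open, it means among the compounds named here.

The three compounds that have been measured share a bicyclic imide core carrying a phenyl ring. Compound 1 `O=C1C2=C(CCCC2)C(=O)N1c1ccccc1` is the bare parent and in an assay on isolated protein (Echinochloa esculenta) for inhibition of protoporphyrinogen oxidase, chloroplastic (Oryza sativa subsp. japonica), using a Dixon plot, with a stated time of 5 min (a higher number here means a weaker inhibitor, a lower number a stronger inhibitor), compound 1 gives 1260 nM. Compound 2 `C#CCN1C(=O)COc2ccc(N3C(=O)C4=C(CCCC4)C3=O)cc21` carries a much more elaborate fused ring system on the phenyl, and in this assay compound 2 gives 1.59 nM. Compound 3 `O=C1C2=C(CCCC2)C(=O)N1c1ccccc1F` has a single fluoro group on the phenyl ring, and in this assay compound 3 gives 3160 nM, the highest number of the three and therefore the weakest inhibitor among them. Among the measured compounds shown here, the only single-point step measured so far is a 2.5-fold higher number from compound 1 to compound 3 (0.40 log units; beyond the scatter).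

Compound 4 `O=C1C2=C(CCCC2)C(=O)N1c1ccc(Cl)cc1F` differs from compound 3 by chloro in place of hydrogen on an aromatic carbon. For the measured compounds named here, no measured pair shows the effect of a chloro group on its own, so the expectation rests on two observations: the fluoro step, which moved the number up only modestly, and compound 2, whose far lower number shows that substitution on this phenyl ring can bring a very large gain. A chloro group is a smaller change than that, so a gain that is clear but well short of compound 2 is expected.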

Compound 4, half-maximal inhibitory concentration: 5.01 nM
Compound 4: middle estimate off by 50-fold (1.70 log units), on the high side; measured number outside the range, below it.
By their numbers in this assay, from the lowest: compound 2; then compound 4; then compound 1; then compound 3.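

In this assay, putting chloro in place of hydrogen gives a 630-fold lower number from compound 3 to compound 4 (2.80 log units; beyond the scatter), so this aromatic carbon, para to a large group and meta to a fluoro group, is a place where one added heavy atom can change the number enormously. Among the compounds shown here, until now, the only single-place step was a 2.5-fold higher number from compound 1 to compound 3 (0.40 log units; beyond the scatter), a modest change towards weaker inhibition, so the earlier compounds gave no sign that so small a change on this ring could bring such a large gain in strength. No measurement of any other kind is available to explain the size of this step, and the numbers record only that it happened.

The compounds shown leave open whether the chloro group would bring the same gain on a phenyl ring without the fluoro group, as this step is seen only with that fluoro group in place. On these data alone, it also remains open whether a bromo group, a methyl group or an amine on this same carbon would match the chloro group, fall well short of it or go further.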